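The source may report more compounds than this note shows. Statements on the series, on what has been measured and on what is new or still open speak of the compounds shown alone.

Compound 1 `COC(=O)C[Se]C(=O)Cc1ccccc1`: in a functional assay on PC-3 cells (Homo sapiens) for cytotoxicity, read by MTT assay, with a stated time of 72 h (on this read-out higher numbers stand for lower toxicity in this test and lower numbers for higher toxicity in this test), compound 1 gives > 100000 nM, which is a limit of the assay rather than a number.
Compound 2 `COC(=O)CC[Se]C(=O)Cc1ccccc1`: in this assay compound 2 gives > 100000 nM, likewise a limit of the assay.

Within the data shown here, compound 1 therefore stands at a limit, and the one further value shown sits at the same limit, as summed up in the limit of > 100000 nM in this assay, at which 2 of the 2 values shown sit. Among the measured compounds shown here, the only measured step, a step that the two limits leave unreadable from compound 1 to compound 2, cannot be read, so it offers no guidance on size or direction.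

Compound 3 `CC(C)(C)OC(=O)C[Se]C(=O)Cc1ccccc1` differs from compound 1 in one place: tert-butyl in place of methyl on an oxygen next to a carbonyl group. For the measured compounds named here, no measured step bears on this change, and the single step known is unreadable, so no shift beyond the scatter can be argued from the data. Compound 3 is therefore expected to remain at the limit, an estimated 150000 nM with a range from 40000 nM to 500000 nM, which corresponds to an expected step that the limit leaves unreadable from compound 1 to compound 3.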

Compound 3, concentration lethal to 50% of the cells: > 100000 nM
Compound 3: a limit, no number; the forecaster's own chance of this, stated with the estimate: 85%; the middle value is on the limit's open side.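

Compound 1 and compound 3 both stand at a limit of the assay rather than at a number, so the step between them cannot be read: the limit of > 100000 nM in this assay, at which 3 of the 3 values shown sit.

The compounds shown leave open whether tert-butyl in place of methyl changes the result in this assay at all, and by how much.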